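The source may hold more compounds than are shown below. What is called first, only, known or untested is meant among the compounds shown, and "the series" means these compounds.

Measured so far:

- compound 1, `CS(=O)(=O)N(CC(=O)N[C@H](C#N)CC(N)=O)Cc1ccc(-c2cccc(F)c2F)cc1`, in an assay on isolated protein for inhibition of legumain (Homo sapiens), with stated times of 2 min and 60 min; on this read-out lower numbers stand for stronger inhibition and higher numbers for weaker inhibition: > 10000 nM, a limit of the assay and not a number
- compound 2, `C[C@@H](C(=O)N[C@H](C#N)CC(N)=O)N(Cc1ccc(-c2ccc(F)c(F)c2)cc1)S(C)(=O)=O`, in this assay: 252 nM
- compound 3, `CS(=O)(=O)N(CC(=O)N[C@H](C#N)CC(N)=O)Cc1ccc(-c2cccc(F)c2)cc1`, in this assay: > 10000 nM, again a limit of the assay and not a number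

Among the measured compounds shown here, compound 2 is thus the only compound of the three with a number in this assay; the other two values shown are limits. From compound 1 to compound 3 the change is hydrogen in place of fluoro on an aromatic carbon. The step that the two limits leave unreadable from compound 1 to compound 3 cannot be sized because of the limit of > 10000 nM in this assay, at which 2 of the 3 values shown sit.

How the core of compound 2 differs from that of compound 1 is not broken down here.

Compound 4, `C[C@@H](C(=O)N[C@H](C#N)CC(N)=O)N(Cc1ccc(-c2ccc(F)cc2)cc1)S(C)(=O)=O`, is not yet measured in this assay. It differs from compound 2 by hydrogen in place of fluoro on an aromatic carbon. This is the same kind of change as from compound 1 to compound 3, but not the same: in compound 1 the leaving fluoro sits ortho to a fluoro group and ortho to a large group, whereas in compound 2 it sits ortho to a fluoro group and meta to a large group. The earlier step is unreadable and gives no size to lean on.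

The expectation for compound 4 therefore rests on compound 2 at 252 nM, with an expected step of a 1.8-fold higher number from compound 2 to compound 4 (0.25 log units; within the scatter). Compound 4 is estimated at 450 nM in this assay, expected to lie between 130 nM and 1600 nM.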

Compound 4, half-maximal inhibitory concentration: 1040 nM
Compound 4: middle estimate off by 2.3-fold (0.36 log units), on the low side; measured number inside the range.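

On the core of compound 2, in this assay, hydrogen in place of fluoro on an aromatic carbon, read as 3,4-difluorophenyl to 4-fluorophenyl, gives a 4.1-fold higher number from compound 2 to compound 4 (0.62 log units; beyond the scatter), so on this core the fluoro that leaves carries a measurable share of the inhibition. Among the compounds shown here, the same kind of change on the core of compound 1, leading to compound 3, cannot be read, because both values are limits of the assay and not numbers: the limit of > 10000 nM in this assay, at which 2 of the 4 values shown sit. The change therefore has a size on one core only, and nothing here shows that this size carries over to the other core, the more so as the fluoro leaves from a different place there than the one in compound 2, where it sits ortho to a fluoro group and meta to a large group.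

Going by these compounds, with a single readable pair, it stays open whether the step depends on the core, on the place of the fluoro, or on both. Also open, on these data alone, is what a chloro group, a methoxy group or an amine would give on that aromatic carbon of compound 2 in place of the fluoro.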